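A few compounds are considered here, and "the series" means these few. Any claim that something is new, unique, unknown or untested is made for them only; others in the source may bear on it.

This study follows a small set of compounds sharing one core, tested in a functional assay on MCF7 cells (Homo sapiens) for cytotoxicity, read by MTT assay, with a stated time of 72 h; on this read-out lower numbers stand for higher toxicity in this test and higher numbers for lower toxicity in this test. Compound 1 `CSc1ccc(CNc2nc([SeH])nc3ccccc23)cc1` carries a methylsulfanyl group on its outer ring and a selenol on the core. In this assay compound 1 reaches only the limit of > 100000 nM, the edge of what the test can report rather than a measured number. Compound 2 `COc1ccc(CNc2nc(SC)nc3ccccc23)cc1` instead bears a methoxy group on the outer ring and a methylsulfanyl on the core. In this assay compound 2 likewise gives only the limit of > 100000 nM. Every value shown so far therefore sits at the limit of > 100000 nM in this assay, at which 2 of the 2 values shown sit, so compound 2 stands exactly where compound 1 stands, with no finer number available. Compound 3 `CSc1ccc(CNc2nc(SC)nc3ccccc23)cc1` is the next candidate. It differs from compound 2 by methylsulfanyl in place of methoxy on an aromatic carbon. Among the compounds with values here, no step between measured compounds exists to guide the expectation, and both measured compounds sit at the limit. The expected step, a number no higher from compound 2 to compound 3 (the limit leaves the size open), is none beyond the usual scatter. Compound 3 is estimated at 100000 nM, within a range from 30000 nM to 300000 nM, most likely reported again only as a limit.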

Compound 3, concentration lethal to 50% of the cells: > 100000 nM
Compound 3 was reported as a limit; the forecaster's own chance of this, stated with the estimate: 80%; the middle value lies on the limit itself.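

Compound 3 is again reported only as a limit in this assay, so no step from compound 2 or compound 1 to compound 3 can be read: the limit of > 100000 nM in this assay, at which 3 of the 3 values shown sit.

The compounds shown leave open how toxic any of the three actually is in this assay, and whether swapping methoxy for methylsulfanyl on the outer ring, or selenol for methylsulfanyl on the core, changes anything.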